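The source may hold more compounds than are shown below. What is called first, only, known or untested is meant among the compounds shown, and "the series" means these compounds.

Measured compounds:
- compound 1 `COc1cccc(Oc2c(NS(=O)(=O)c3ccc(C(C)(C)C)cc3)ncnc2OCCOc2nccs2)c1`; in an assay on cells (Endothelial cell) for binding affinity to Endothelin-1 receptor (Sus scrofa) (on this read-out higher numbers stand for weaker inhibition and lower numbers for stronger inhibition), compound 1 gives 12 nM
- compound 2 `COc1cccc(Oc2c(NS(=O)(=O)c3ccc(C(C)(C)C)cc3)ncnc2OCCOc2ncc(Br)cn2)c1`; in this assay compound 2 gives 0.051 nM
- compound 3 `CCC(C)(C)c1ccc(S(=O)(=O)Nc2ncnc(OCCOc3ncc(Br)cn3)c2-c2ccc(C)cc2)cc1`; in this assay compound 3 gives only a limit, < 0.001 nM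

Compound 3 stands at the assay limit (the limit of < 0.001 nM in this assay, at which 1 of the 3 values shown sits); its true number is not known, only that it lies beyond the range the assay resolves. Compound 4 `Cc1ccc(-c2c(NS(=O)(=O)c3ccc(I)cc3)ncnc2OCCOc2ncc(Br)cn2)cc1` differs from compound 3 by iodo in place of 1,1-dimethylpropyl on an aromatic carbon.

Within the data shown here, the one measured step, a 240-fold lower number from compound 1 to compound 2 (2.37 log units; beyond the scatter), concerns the group on the oxygen on the saturated carbon and does not touch the sulfonamide aryl group, so no measured step bears on the change from compound 3 to compound 4. With compound 3 at a limit, the size of the step cannot be anchored from either side. Compound 4 is expected to sit above the limit with a step of an at least 10-fold higher number from compound 3 to compound 4 (1.00 log units; beyond the scatter); compound 4 is estimated at 0.01 nM, between 0.001 nM and 0.3 nM.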

Compound 4, half-maximal inhibitory concentration: 1 nM
Estimate against measurement, compound 4: 100-fold (2.00 log units) below, outside the stated range (above it).
By their numbers in this assay, from the lowest: compound 2; then compound 4; then compound 1. At a limit, below all of these: compound 3.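

Exchanging 4-(1,1-dimethylpropyl)phenyl for 4-iodophenyl moves the number in this assay by a large step (an at least 1000-fold higher number from compound 3 to compound 4 (3.00 log units; beyond the scatter)), so the sulfonamide aryl group, untouched by the earlier step, is a second place in the series that responds strongly. Compound 3 stands at a limit, so the step has a floor but no known size: the limit of < 0.001 nM in this assay, at which 1 of the 4 values shown sits.

The compounds shown leave open how an amine, a carboxylic acid or a methoxy group would read on this aromatic carbon. On these data alone, whether the same exchange gives a step of similar size on the core of compound 2 also remains open.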